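Swapping cyclohexyl for phenyl on an alkyne-bearing nucleoside

The source may report more compounds than this note shows. Statements on the series, on what has been measured and on what is new or still open speak of the compounds shown alone.

Measured compounds:
- compound 1, `O=c1[nH]c(=O)n([C@@H]2O[C@H](CO)[C@@H](O)[C@H]2O)cc1C#CC1CCCCC1`: 36800 nM
- compound 2, `CCCCCCC#Cc1c[nH]c(=O)[nH]c1=O`: 94900 nM
- compound 3, `O=c1[nH]cc(C#CC2CC2)c(=O)[nH]1`: 101000 nM

In an ADME assay on MRC5 cells (Homo sapiens) for cytotoxicity, read by MTT assay (on this read-out lower numbers stand for higher toxicity in this test and higher numbers for lower toxicity in this test), compound 1 gives the lowest of the three numbers, and its gaps to compound 2 and compound 3 both lie beyond the scatter. Compound 4, `O=c1[nH]c(=O)n([C@@H]2O[C@H](CO)[C@@H](O)[C@H]2O)cc1C#Cc1ccccc1`, has not yet been measured. It differs from compound 1 only in one place: phenyl in place of cyclohexyl on a triple-bonded carbon. Among the measured compounds shown here, no measured pair shows this kind of change, so there is nothing to copy from. The exchange of one six-membered carbon ring for another of the same size is expected to shift the read-out only a little, in no firm direction, giving an expected step of a 1.2-fold higher number from compound 1 to compound 4 (0.09 log units; within the scatter) that stays within the scatter. The estimate for compound 4 is therefore 45000 nM, in a range from 15000 nM to 120000 nM.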

Compound 4, half-maximal cytotoxic concentration: 1200 nM
For compound 4 the middle estimate is 38-fold (1.57 log units) above the measured one; measured number below the stated range.
By their numbers in this assay, from the lowest: compound 4; then compound 1; then compounds 2 and 3 (each within the scatter of the next).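

In this assay, the group on the triple-bonded carbon turns out to matter greatly: phenyl in place of cyclohexyl gives a 31-fold lower number from compound 1 to compound 4 (1.49 log units; beyond the scatter), which here means higher toxicity in this test. The two rings match in size and differ only in being aromatic or non-aromatic, so this position responds strongly to a change that leaves the counted features alike. Nothing available explains why the aromatic ring has this effect. Still open, from the compounds shown here alone, is whether a pyridyl ring or an aminophenyl group in this place would give a number closer to compound 4 or to compound 1.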